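The source may hold more compounds than are shown below. What is called first, only, known or untested is meant among the compounds shown, and "the series" means these compounds.

Working notes on the series. The shared core is carried by compound 1 `O=C(Nc1ccc(Cl)c(-c2nnc3c(Cl)cccn23)c1)c1ccc(Cl)cc1`, compound 2 `O=C(Nc1ccc(Cl)c(-c2nnc3c(Cl)cccn23)c1)c1cccc(Cl)c1`, compound 3 `CS(=O)(=O)c1ccc(C(=O)Nc2ccc(Cl)c(-c3nnc4c(Cl)cccn34)c2)cc1` and the not yet measured compound 4 `O=C(Nc1ccc(Cl)c(-c2nnc3c(Cl)cccn23)c1)c1ccc(Cl)cc1Cl`. In a functional assay on U-251 cells (Homo sapiens) for antiproliferative activity, read by MTT assay, with a stated time of 72 h (on this read-out lower numbers stand for stronger inhibition and higher numbers for weaker inhibition), compound 3 gives > 100000 nM, which is a limit of the assay and not a number. Compound 1 also sits at a limit, > 100000 nM. For the measured compounds named here, compound 2 gives 43100 nM, the only number in the set. Two of three values share (the limit of > 100000 nM in this assay, at which 2 of the 3 values shown sit). The change 2,4-dichlorophenyl in place of 4-(methylsulfonyl)phenyl on a carbonyl carbon touches the same carbonyl carbon as the measured steps: an at least 2.3-fold lower number from compound 1 to compound 2 (0.36 log units; beyond the scatter), an at least 2.3-fold higher number from compound 2 to compound 3 (0.36 log units; beyond the scatter), while a step that the two limits leave unreadable from compound 1 to compound 3. Compound 4 keeps the 4-chlorophenyl pattern of compound 1 with a second chloro added, so weak activity near a limit is expected. Compound 4 is estimated at 90000 nM, range 30000 nM to 300000 nM. The estimated step is an at least 1.1-fold lower number from compound 3 to compound 4 (0.04 log units; that floor lies within the scatter).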

Compound 4, half-maximal inhibitory concentration: > 100000 nM
Compound 4: a limit, no number; the forecaster's own chance of this, stated with the estimate: 60%; middle value at least 1.1-fold (0.04 log units) from the limit.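

In this assay the value of compound 4 is a limit of the assay and not a number, and its steps from compound 1 and compound 3 cannot be read. Moving to 2,4-dichlorophenyl on the carbonyl carbon gives an at least 2.3-fold higher number from compound 2 to compound 4 (0.36 log units; beyond the scatter), so adding a second chloro to the 4-chlorophenyl pattern does not yield a number, and compound 2 remains the only compound with one. Most of the series now sits at one place: the limit of > 100000 nM in this assay, at which 3 of the 4 values shown sit.

On these data alone, how far the groups at the limit differ stays open. Also open, as far as these compounds go, is what a phenyl carrying an amine or a carboxylic acid would give on this carbonyl carbon.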